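Adding a Chloro Group to Compound 1: Expected Cytotoxicity

This account rests on a few compounds, and the source may have more. Where it says the series, first, only, none or still open, it means among the compounds named here.

Measured so far:
compound 1 `NS(=O)(=O)c1ccc(NC(=O)CSc2nnc(N3C(=O)CSC3c3ccccc3)s2)cc1` — 99200 nM
compound 2 `O=C1CSC(c2ccccc2)N1c1nnc(S)s1` — > 423000 nM, a limit of the assay rather than a number
compound 3 `O=C1CSC(c2ccc(Cl)cc2)N1c1n[nH]c(=S)s1` — 195000 nM

In an ADME assay on MT4 cells (Homo sapiens) for cytotoxicity, read by MTT assay, with a stated time of 5 days (a higher number here means that more compound is tolerated, a lower number that less compound is tolerated), compound 1 gives 99200 nM, the lowest of the two numbers shown. Compound 3 gives 195000 nM, which lies within the scatter of compound 1. For compound 2 the result is only a limit of this assay. One of the three values sits at the limit of > 423000 nM in this assay, at which 1 of the 3 values shown sits.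

Compound 4 `NS(=O)(=O)c1ccc(NC(=O)CSc2nnc(N3C(=O)CSC3c3cccc(Cl)c3)s2)cc1` differs from compound 1 by chloro in place of hydrogen on an aromatic carbon. Going by the values given here, no measured pair differs in this way alone, so no step beyond the scatter is expected in this assay. Compound 4 is therefore estimated at 100000 nM, between 40000 nM and 250000 nM. The expected step is a 1.0-fold higher number from compound 1 to compound 4 (0.00 log units; within the scatter).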

Compound 4, half-maximal cytotoxic concentration: 118000 nM
For compound 4 the middle estimate is 1.2-fold (0.07 log units) below the measured one; the measured number falls inside the stated range.
By their numbers in this assay, from the lowest: compounds 1, 4 and 3 (each within the scatter of the next). At a limit, above all of these: compound 2.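

Going by these compounds alone, this pair is the first in which a single change can be read: phenyl to 3-chlorophenyl gives, in this assay, a 1.2-fold higher number from compound 1 to compound 4 (0.08 log units; within the scatter). A chloro in place of hydrogen on this aromatic carbon, meta to a large group, therefore leaves the tolerated concentration indistinguishable from that of the unsubstituted phenyl. The earlier compounds shown here, which differ from one another in more than one place or end at a limit, could not show this.

On these data alone, whether an amine or a carboxylic acid on this same carbon would also stay within the scatter remains open. Nothing shown gives a reason for this result.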